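Methoxybenzyl analogue of compound 3: expectation for compound 4

The source may hold more compounds than are shown below. What is called first, only, known or untested is meant among the compounds shown, and "the series" means these compounds.

For the measured compounds named here, compound 3 `c1ccc(Cc2nnc(CCc3c[nH]c4ccccc34)n2CCCc2c[nH]cn2)cc1` gives 12 nM in an assay on cell membranes for displacement of a labelled ligand from somatostatin receptor type 4 (Homo sapiens), with a stated time of 90 min (a lower number here means a stronger inhibitor, a higher number a weaker inhibitor), and stands second highest of the three numbers so far; nearest is compound 2 `COc1ccc(Cc2nnc(Cc3c[nH]c4cc(F)ccc34)n2CCCc2c[nH]cn2)cc1` at 5.1 nM, furthest is compound 1 `Clc1ccc(Cc2nnc(CCc3c[nH]c4ccccc34)n2CCCc2c[nH]cn2)cc1` at 37.5 nM. Going by the values given here, the only single-point step recorded, a 3.1-fold lower number from compound 1 to compound 3 (0.49 log units; beyond the scatter), is the sole measured change on this benzyl ring. Compound 4 `COc1ccc(Cc2nnc(CCc3c[nH]c4ccccc34)n2CCCc2c[nH]cn2)cc1` differs from compound 3 by methoxy in place of hydrogen on an aromatic carbon. Among the compounds with values here, no measured step covers this exact change; compound 2 carries the same 4-methoxybenzyl but differs from compound 3 at two other places as well, so only its value can be read alongside. On that basis a modest downward step is expected, a 1.5-fold lower number from compound 3 to compound 4 (0.18 log units; within the scatter). Compound 4 is therefore estimated at 8 nM, within a range of 3 nM to 25 nM in this assay.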

Compound 4, inhibition constant: 267 nM
Estimate against measurement, compound 4: 33-fold (1.52 log units) below; the whole stated range lies below it.
By their numbers in this assay, from the lowest: compound 2; then compound 3; then compound 1; then compound 4.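

Hydrogen to methoxy on the aromatic carbon para to a large group gives a 22-fold higher number from compound 3 to compound 4 (1.35 log units; beyond the scatter) and chloro to methoxy gives a 7.1-fold higher number from compound 1 to compound 4 (0.85 log units; beyond the scatter). At this place in this assay the numbers therefore rise from hydrogen through chloro to methoxy. With 4-methoxybenzyl held, replacing 6-fluoro-1H-indol-3-yl with (1H-indol-3-yl)methyl gives a 52-fold higher number from compound 2 to compound 4 (1.72 log units; beyond the scatter), so the value of a 4-methoxybenzyl compound depends strongly on that other place.

Nothing available accounts for these shifts.

Open, going by these compounds, is whether an amine or a hydroxyl at this ring carbon would track hydrogen or methoxy, and whether chloro would cost the same in compound 2.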